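The source may report more compounds than this note shows. Statements on the series, on what has been measured and on what is new or still open speak of the compounds shown alone.

Measured compounds and values:

compound 1, `Cc1ccc(-c2cc(NO)c(C(=O)NCCO)c(=O)o2)cc1` — > 20000 nM
compound 2, `COc1ccc(-c2cc(NO)c(C(=O)NCCO)c(=O)o2)cc1` — > 20000 nM
compound 3, `COC(=O)CNC(=O)c1c(NO)cc(-c2ccc(C)cc2)oc1=O` — > 20000 nM

All three were tested in an ADME assay on Huh-7 cells (Homo sapiens) for cytotoxicity, read by a luciferase reporter and WST assay, with a stated time of 3 days; on this read-out lower numbers stand for higher toxicity in this test and higher numbers for lower toxicity in this test. The value of compound 1 in this assay is a limit of the test and not a number. The value of compound 2 is likewise a limit. The value of compound 3 is also a limit. Compound 1 and compound 2 differ by methoxy in place of methyl on an aromatic carbon, and the step in this assay is a step that the two limits leave unreadable from compound 1 to compound 2; it cannot be read because of the limit of > 20000 nM in this assay, at which 3 of the 3 values shown sit. Compound 3 differs from compound 1 in its core by methoxycarbonyl in place of hydroxymethyl on a saturated chain carbon bound to an amide-type nitrogen, and the step from compound 1 to compound 3 is a step that the two limits leave unreadable from compound 1 to compound 3.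

Compound 4, `COC(=O)CNC(=O)c1c(NO)cc(-c2ccc(OC)cc2)oc1=O`, is not yet measured. It differs from compound 3 by methoxy in place of methyl on an aromatic carbon, the same change that turns compound 1 into compound 2. The step from compound 3 to compound 4 in this assay is expected to be a step that the limit leaves unreadable from compound 3 to compound 4, which rests on the limit value of compound 1 and the limit value of compound 2 both lying at the same place. Compound 4 is therefore estimated at 30000 nM, most likely reported again only as a limit.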

Compound 4, half-maximal cytotoxic concentration: > 20000 nM
Compound 4: a limit, no number; the forecaster's own chance of this, stated with the estimate: 85%; the middle value does not contradict the limit.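

The steps from compound 3 to compound 4 and from compound 2 to compound 4 cannot be read in this assay, because the values at both ends of each step are limits and not numbers: the limit of > 20000 nM in this assay, at which 4 of the 4 values shown sit.

The compounds shown leave open whether methoxy in place of methyl, or methoxycarbonyl in place of hydroxymethyl, changes the cytotoxic concentration at all.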